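Diethyl amide in place of a hydroxyethyl amide

The source may hold more compounds than are shown below. What is called first, only, known or untested is meant among the compounds shown, and "the series" means these compounds.

Compound 1 `COc1cc(-n2cccc2C(=O)N2CCCC2)ccc1Nc1ncc(Cl)c(Nc2ccccc2NS(C)(=O)=O)n1`: in a functional assay on A549 cells (Homo sapiens) for antiproliferative activity, read by MTT assay, with a stated time of 72 h (on this read-out lower numbers stand for stronger inhibition and higher numbers for weaker inhibition), compound 1 gives 4580 nM.
Compound 2 `COc1cc(-n2cccc2C(=O)NCCO)ccc1Nc1ncc(Cl)c(Nc2ccccc2NS(C)(=O)=O)n1`: in this assay compound 2 reaches only a limit, > 10000 nM.

The two measured compounds share one core and differ only in the amine bound to the carbonyl carbon. The change from pyrrolidin-1-yl to (2-hydroxyethyl)amino gives an at least 2.1-fold higher number from compound 1 to compound 2 (0.33 log units; beyond the scatter). As far as these compounds go, compound 2 thus stands at the limit of > 10000 nM in this assay, at which 1 of the 2 values shown sits, and how far beyond it the true number lies is unknown.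

Compound 3 `CCN(CC)C(=O)c1cccn1-c1ccc(Nc2ncc(Cl)c(Nc3ccccc3NS(C)(=O)=O)n2)c(OC)c1` differs from compound 2 by diethylamino in place of (2-hydroxyethyl)amino on a carbonyl carbon. This returns to a tertiary amide without hydrogen-bond donors, as in compound 1. For the measured compounds named here, the single measured step that bears on the change is the one from compound 1 to compound 2, which went toward a weaker number when the donor-bearing group entered; reversing that kind of change is expected to move the number back down. Compound 3 is therefore expected to land near compound 1, a step of an at least 2.0-fold lower number from compound 2 to compound 3 (0.30 log units; that floor lies within the scatter). Compound 3 is estimated at 5000 nM, within 2000 nM to 14000 nM.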

Compound 3, half-maximal inhibitory concentration: 970 nM
The estimate for compound 3 lay 5.2-fold (0.71 log units) above the measured number; the whole stated range lies above it.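

In this assay the two amides without hydrogen-bond donors are not interchangeable, with a 4.7-fold lower number from compound 1 to compound 3 (0.67 log units; beyond the scatter), so the open-chain diethylamino group does more than return to the level of the pyrrolidin-1-yl ring. The other step, an at least 10-fold lower number from compound 2 to compound 3 (1.01 log units; beyond the scatter), is a floor rather than a full measure of the change. Compound 2 has only a limit, not a number: the limit of > 10000 nM in this assay, at which 1 of the 3 values shown sits.

As far as these compounds go, what remains open is how far the effect of the amine extends: dimethylamino, dipropylamino or morpholin-4-yl on the same carbonyl carbon could show whether the diethylamino result is a peak or part of a longer trend. The compounds shown also cannot separate the loss of the hydroxyl group from the loss of the amide hydrogen, a question that a 2-methoxyethylamino group could address.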